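This account rests on a few compounds, and the source may have more. Where it says the series, first, only, none or still open, it means among the compounds named here.

In an ADME assay on MDCKII-LE cells (Canis lupus familiaris) for permeability (a higher number here means that the compound crosses the layer faster, a lower number that the compound crosses the layer more slowly), compound 1 (`Cc1cnc(NC(=O)c2cc(Oc3ccc(C(=O)N(C)C)cc3)c3cc(C)oc3c2)cn1`) gives 5.9 10^-6 cm/s and compound 2 (`COC1CN(C(=O)c2cnc(Oc3cc(C(=O)Nc4cnccn4)cc4oc(C)cc34)cn2)C1`) gives 21.8 10^-6 cm/s in the same measurement. Compound 3 (`Cc1ccc(NC(=O)c2cc(Oc3cnc(C(=O)N(C)C)cn3)c3cc(C)oc3c2)nc1`) gives 21.5 10^-6 cm/s and so stands level with compound 2 within the scatter, while compound 1 lies lower by more than the scatter.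

Compound 4 (`Cc1cc2c(Oc3cnc(C(=O)N(C)C)cn3)cc(C(=O)Nc3cnc(C(F)(F)F)cn3)cc2o1`) is read against compound 3. It carries 5-(trifluoromethyl)pyrazin-2-yl in place of 5-methylpyridin-2-yl on an amide-type nitrogen and is otherwise unchanged.

For the measured compounds named here, no two measured compounds differ in one place only, so the series gives no direct measure of a change at this nitrogen. Compound 2 and compound 3 differ there and elsewhere in the structure, and the values of compound 2 at 21.8 10^-6 cm/s and compound 3 at 21.5 10^-6 cm/s show no gap beyond the scatter. That is weak support, but it gives no reason to expect a large move. In this assay the expectation is therefore a slightly lower number or no change beyond the scatter. The estimated step is a 1.2-fold lower number from compound 3 to compound 4 (0.08 log units; within the scatter) and stays within the scatter. For compound 4 the estimate is 18 10^-6 cm/s with an expected range from 9 10^-6 cm/s to 36 10^-6 cm/s in this measurement.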

Compound 4, apparent permeability: 9.7 10^-6 cm/s
For compound 4 the middle estimate is 1.9-fold (0.27 log units) above the measured one, within the range that was stated.
By their numbers in this assay, from the lowest: compounds 1 and 4 (each within the scatter of the next); then compounds 3 and 2 (each within the scatter of the next).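

In this assay, for the compounds shown here, 5-(trifluoromethyl)pyrazin-2-yl in place of 5-methylpyridin-2-yl on the amide-type nitrogen gives a 2.2-fold lower number from compound 3 to compound 4 (0.35 log units; beyond the scatter), the first step that isolates a change at this place and the first sign that the read-out responds to the group carried there. The step is modest, and compound 4 at 9.7 10^-6 cm/s remains a measured single case for this change, but it shows that this exchange of groups is not neutral when the rest of the structure is held constant. The exchange alters the ring hetero atoms and the ring substituent together, and no measurement at hand accounts for the step.

Going by these compounds, how much of the step belongs to the ring and how much to the trifluoromethyl group stays open, and a 5-(trifluoromethyl)pyridin-2-yl group on the same nitrogen would separate the two. Whether a step of this size recurs with a different group in place of the dimethylamide, or on the core of compound 1, also remains unanswered.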